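Solubility of a quinoline series: from methoxyphenoxy to benzyl

This account rests on a few compounds, and the source may have more. Where it says the series, first, only, none or still open, it means among the compounds named here.

Measured compounds:
compound 1 `COc1cccc(CNCCCNc2ccnc3cc(Cc4ccccc4)ccc23)c1O`: 4200 nM
compound 2 `Cc1cc(C)cc(Cc2ccc3c(NCCCNCc4ccco4)ccnc3c2)c1`: 4200 nM
compound 3 `COc1cccc(Oc2ccc3c(NCCCNCc4ccco4)ccnc3c2)c1`: 14500 nM

Of the compounds shown here, three sharing one core have been tested in a physicochemical assay for solubility, with a stated time of 18 h, at pH 7.4; on this read-out higher numbers stand for higher solubility and lower numbers for lower solubility. Compound 1 gives 4200 nM and compound 2 gives 4200 nM; these two values lie within the scatter of each other. Compound 3 gives 14500 nM and stands highest of the three, with a gap beyond the scatter to both compound 1 and compound 2 a 3.5-fold higher number from compound 2 to compound 3 (0.54 log units; beyond the scatter).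

The next compound, compound 4 `c1ccc(Cc2ccc3c(NCCCNCc4ccco4)ccnc3c2)cc1`, has not yet been measured in this assay. It differs from compound 3 at one place: benzyl in place of 3-methoxyphenoxy on an aromatic carbon.

Among the compounds with values here, the single measured step that bears on this change is the one from compound 2 to compound 3 a 3.5-fold higher number from compound 2 to compound 3 (0.54 log units; beyond the scatter), where a benzyl-type group gave way to 3-methoxyphenoxy and the number rose. Compound 4 runs that change backward, though its benzyl lacks the two methyls of compound 2. A drop of similar size, back toward the level of compound 2, is therefore expected, and compound 4 is estimated at 5000 nM, in the range 2500 nM to 10000 nM, which means an expected step of a 2.9-fold lower number from compound 3 to compound 4 (0.46 log units; beyond the scatter).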

Compound 4, solubility: 4200 nM
Beside the measured number, compound 4's estimate is 1.2-fold (0.08 log units) above it; measured number inside the range.
By their numbers in this assay, from the lowest: compounds 1, 2 and 4 (each within the scatter of the next); then compound 3.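

In this assay, the change of benzyl in place of 3-methoxyphenoxy on this aromatic carbon now stands as a direct step (a 3.5-fold lower number from compound 3 to compound 4 (0.54 log units; beyond the scatter)), so compound 3 stands apart from a plain benzyl as well as from 3,5-dimethylbenzyl. Phenyl in place of 3,5-dimethylphenyl on the saturated chain carbon bound to an aromatic carbon gives no change at the digits printed from compound 2 to compound 4 (within the scatter) and furan-2-yl in place of 2-hydroxy-3-methoxyphenyl on the saturated chain carbon bound to an amine nitrogen gives no change at the digits printed from compound 1 to compound 4 (within the scatter) as well. Among these four compounds, the only step beyond the scatter that involves compound 4 is therefore the one at the 3-methoxyphenoxy position, and compound 3 is the only one that carries that group.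

Going by these compounds, whether the higher number of compound 3 goes with the ether oxygen or with the methoxy group stays open, as does what a plain phenoxy, a 3-methoxybenzyl or an amine such as morpholin-4-yl on this aromatic carbon would give. No measurement at hand accounts for the step at this position.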